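The source may report more compounds than this note shows. Statements on the series, on what has been measured and on what is new or still open speak of the compounds shown alone.

In an ADME assay on HeLa cells (Homo sapiens) for cytotoxicity, read by resazurin assay, with a stated time of 2 days (a lower number here means a stronger inhibitor, a higher number a weaker inhibitor), compound 1 `Cn1c([N+](=O)[O-])cnc1/C=C/c1ccc2ccccc2c1` gives 97700 nM, compound 2 `Cn1ccnc1/C=C/c1ncc([N+](=O)[O-])n1C` gives 91200 nM and compound 3 `Cn1c([N+](=O)[O-])cnc1/C=C/c1ccco1` gives 93300 nM. Compound 3 therefore cannot be ranked against the other two, since all three numbers lie within the usual scatter of one another. Compound 4 `Cn1c([N+](=O)[O-])cnc1/C=C/c1cccs1` carries thiophen-2-yl in place of furan-2-yl on a double-bonded chain carbon bound to a double-bonded chain carbon. Within the data shown here, no measured pair shows this exact swap. However, different groups on that chain leave the numbers within the scatter, so no step beyond the scatter is expected in this assay. The expected result is a 1.1-fold lower number from compound 3 to compound 4 (0.04 log units; within the scatter), which stays within the scatter. For compound 4 the estimated value is 85000 nM, with an expected range from 45000 nM to 120000 nM.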

Compound 4, half-maximal inhibitory concentration: 91200 nM
Beside the measured number, compound 4's estimate is 1.1-fold (0.03 log units) below it, within the range that was stated.
By their numbers in this assay, from the lowest: compounds 2, 4, 3 and 1 (each within the scatter of the next).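

In this assay, thiophen-2-yl in place of furan-2-yl on a double-bonded chain carbon bound to a double-bonded chain carbon gives a 1.0-fold lower number from compound 3 to compound 4 (0.01 log units; within the scatter). Among these compounds, this is the first step that isolates one change at this place, and exchanging the ring oxygen for sulfur leaves the number within the scatter. No measurement here speaks to why.

Going by these compounds, whether an amine or a carboxylic acid at this place would move the number beyond the scatter remains open. With the four compounds each within the scatter of the next, no structural feature can yet be linked to the read-out.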